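The source may report more compounds than this note shows. Statements on the series, on what has been measured and on what is new or still open speak of the compounds shown alone.

Three compounds have been measured in a functional assay on HUVEC cells (Homo sapiens) for cytotoxicity; on this read-out lower numbers stand for an effect already at smaller amounts and higher numbers for an effect only at larger amounts of compound:

Compound 1 `COC1=C(C)C(=O)/C(=C(O)/C=C/c2ccc(Br)cc2)C(=O)C1(C)C`: 3.6 ug/mL
Compound 2 `COC1=C(C)C(=O)/C(=C(O)/C=C/c2ccc(OC)cc2)C(=O)C1(C)C`: 2.5 ug/mL
Compound 3 `COC1=C(C)C(=O)/C(=C(O)/C=C/c2c(C)cccc2C)C(=O)C1(C)C`: 3 ug/mL

Compound 1 gives the highest of the three numbers, but neither neighbour is separated from it by more than the scatter: a 1.2-fold lower number from compound 1 to compound 3 (0.08 log units; within the scatter) and a 1.4-fold lower number from compound 1 to compound 2 (0.16 log units; within the scatter). Likewise a 1.2-fold higher number from compound 2 to compound 3 (0.08 log units; within the scatter). Compound 4 `COC1=C(C)C(=O)/C(=C(O)/C=C/c2ccco2)C(=O)C1(C)C` is not yet measured. It differs from compound 1 in one place: furan-2-yl in place of 4-bromophenyl on a double-bonded chain carbon bound to a double-bonded chain carbon. The two steps that bear on this change both swap the aromatic group at the same place on the chain and both stay within the scatter, so in this assay no step beyond the scatter is expected; the estimated step is a 1.2-fold lower number from compound 1 to compound 4 (0.08 log units; within the scatter). Compound 4 is therefore estimated at 3 ug/mL, with a range from 1.5 ug/mL to 6 ug/mL.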

Compound 4, concentration for half-maximal effect: 2.4 ug/mL
The estimate for compound 4 lay 1.3-fold (0.10 log units) above the measured number, within the range that was stated.
By their numbers in this assay, from the lowest: compounds 4, 2, 3 and 1 (each within the scatter of the next).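

The earlier compounds shown here all carry a six-membered aromatic ring of carbon only at this place on the chain. Furan-2-yl brings a five-membered aromatic ring with one hetero atom, yet in this assay it stays within the scatter of all three (a 1.5-fold lower number from compound 1 to compound 4 (0.18 log units; within the scatter)) (a 1.3-fold lower number from compound 3 to compound 4 (0.10 log units; within the scatter)) (a 1.0-fold lower number from compound 2 to compound 4 (0.02 log units; within the scatter)). Among these four compounds, neither ring size nor that hetero atom separates the numbers, and no measurement given here explains this.

As far as these compounds go, whether an amine, a carboxylic acid or a longer chain at this place would give a step beyond the scatter remains open.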